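Compound 2 to compound 3: a cytotoxicity note

The compounds below may be only part of what the source reports. "The series", "measured", "known", "first", "only" and "open" are said of these compounds alone.

compound 1 `N#Cc1ccc(-c2ccc(Cn3cccc(O)c3=S)cc2)cc1` gives > 10 ug/mL
compound 2 `CN(C)c1ccc(-c2ccc(Cn3cccc(O)c3=O)cc2)cn1` gives > 10 ug/mL
compound 3 `CN(C)c1ccc(-c2ccc(Cn3cccc(O)c3=S)cc2)cn1` is not yet measured

In an ADME assay on THP-1 cells (Homo sapiens) for cytotoxicity, read by resazurin assay, with a stated time of 48 h (on this read-out higher numbers stand for weaker inhibition and lower numbers for stronger inhibition), compound 2 gives > 10 ug/mL as a limit and not a number. Compound 1 gives > 10 ug/mL as a limit too. The change to compound 3 is a group of 8 heavy atoms (5 carbon, 1 nitrogen, 1 oxygen, 1 sulfur; one six-membered aromatic ring with 1 hetero atom) in place of a group of 8 heavy atoms (5 carbon, 1 nitrogen, 2 oxygen; one six-membered aromatic ring with 1 hetero atom), on a saturated chain carbon bound to an aromatic carbon and no other. Among the measured compounds shown here, no measured step is available for this change. For compound 3 the expectation rests on the limit of > 10 ug/mL in this assay, at which 2 of the 2 values shown sit, for compound 1 and compound 2. In this assay the expected step that the limit leaves unreadable from compound 2 to compound 3 stays within the scatter, with no direction expected. Compound 3 is estimated at 14 ug/mL with an expected range of 6 ug/mL to 30 ug/mL in this series.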

Compound 3, half-maximal inhibitory concentration: > 10 ug/mL
Compound 3: no number, only a limit; the forecaster's own chance of this, stated with the estimate: 70%; the middle value lies beyond the limit too.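

Compound 2 and compound 3 both stand as limits and not numbers, and no step between them can be read in this assay: the limit of > 10 ug/mL in this assay, at which 3 of the 3 values shown sit.

The compounds shown leave open whether this exchange of groups alters cytotoxicity at all, and where the true values lie.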